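Hydroxypyridine Amide in Place of Trifluoromethylphenyl Amide

The compounds below may be only part of what the source reports. "The series", "measured", "known", "first", "only" and "open" are said of these compounds alone.

Three amides sharing one core have been measured in an assay on CHO cells for positive allosteric modulation of metabotropic glutamate receptor 5 (Homo sapiens), read by FLIPR; on this read-out lower numbers stand for an effect already at smaller amounts and higher numbers for an effect only at larger amounts of compound. Compound 1 `O=C(Nc1ccc(Cl)cc1CN1C(=O)c2ccccc2C1=O)c1ccccc1` reaches only the limit of the assay, > 100000 nM, so no number exists for it. Compound 2 `O=C(Nc1ccc(Cl)cc1CN1C(=O)c2ccccc2C1=O)c1ccco1` gives 2300 nM, and compound 3 `O=C(Nc1ccc(Cl)cc1CN1C(=O)c2ccccc2C1=O)c1ccccc1C(F)(F)F` gives 5700 nM. Of the two numbers shown, compound 3 stands highest; its nearest neighbour is compound 2, with a 2.5-fold higher number from compound 2 to compound 3 (0.39 log units; beyond the scatter). The next compound, compound 4 `O=C(Nc1ccc(Cl)cc1CN1C(=O)c2ccccc2C1=O)c1ncccc1O`, carries the change (3-hydroxypyridin-2-yl in place of 2-(trifluoromethyl)phenyl on a carbonyl carbon). Among the measured compounds shown here, two measured steps bear on it: an at least 43-fold lower number from compound 1 to compound 2 (1.63 log units; beyond the scatter), where furan-2-yl replaced phenyl, and an at least 17-fold lower number from compound 1 to compound 3 (1.24 log units; beyond the scatter), where trifluoromethyl entered the phenyl. Both moved the number far down from the limit of compound 1, and the step of a 2.5-fold higher number from compound 2 to compound 3 (0.39 log units; beyond the scatter) places the heteroaryl amide below the trifluoromethylphenyl amide. Compound 4 likewise carries a heteroaryl on the carbonyl carbon. On that basis the step of a 2.3-fold lower number from compound 3 to compound 4 (0.36 log units; beyond the scatter) is expected to lower the number modestly. For the measured compounds named here, the hydroxyl on the pyridine has no counterpart among the measured compounds. Compound 4 is therefore estimated at 2500 nM, within 500 nM to 12000 nM.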

Compound 4, half-maximal effective concentration: 260 nM
Compound 4: the middle estimate sits 9.6-fold (0.98 log units) above what was measured; measured number below the stated range.
By their numbers in this assay, from the lowest: compound 4; then compound 2; then compound 3. At a limit, above all of these: compound 1.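

At this place on the carbonyl carbon, the group can move the number much further than the earlier amides showed in this assay: the change gives a 22-fold lower number from compound 3 to compound 4 (1.34 log units; beyond the scatter), and an 8.8-fold lower number from compound 2 to compound 4 (0.95 log units; beyond the scatter), where the two earlier measured amides differed only by a 2.5-fold higher number from compound 2 to compound 3 (0.39 log units; beyond the scatter). Compound 2 also carries a ring with a hetero atom at this place, so such a ring alone does not account for the position of compound 4. Against the plain phenyl the change gives an at least 380-fold lower number from compound 1 to compound 4 (2.58 log units; beyond the scatter), which is only a bound, as compound 1 stands at a limit: the limit of > 100000 nM in this assay, at which 1 of the 4 values shown sits.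

As far as these compounds go, the pyridine nitrogen and the hydroxyl enter together, so what each contributes stays open. A plain pyridine amide, a phenyl amide carrying hydroxyl, or a methoxy in place of the hydroxyl would separate them.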